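This account rests on a few compounds, and the source may have more. Where it says the series, first, only, none or still open, it means among the compounds named here.

Working notes on the series.

Compound 3 `O=C(Nc1ccc([N+](=O)[O-])cc1)c1c(O)c2cccnc2n(-c2ccccc2)c1=O` stands lowest of the three numbers in a functional assay on the whole organism for inhibition, with Rattus norvegicus as the target, read by cytopathic effect and paw edema, at a dose of 100 mg/kg by the oral route (a higher number here means more inhibition at the dose given (going by the name of the read-out), a lower number less inhibition), where compound 3 gives -25.8%. Compound 1 `O=C(NCc1ccccc1)c1c(O)c2cccnc2n(-c2ccccc2)c1=O` gives 11.3% and compound 2 `Cc1ccc(NC(=O)c2c(O)c3cccnc3n(-c3ccccc3)c2=O)cc1` gives 2.2% in this assay. The steps were a number 9.1 percentage points lower from compound 1 to compound 2 (within the scatter), a number 37.1 percentage points lower from compound 1 to compound 3 (beyond the scatter) and a number 28 percentage points lower from compound 2 to compound 3 (beyond the scatter).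

Compound 4 `Nc1ccc(NC(=O)c2c(O)c3cccnc3n(-c3ccccc3)c2=O)cc1` differs from compound 3 in one place: amino in place of nitro on an aromatic carbon. The step that bears on it is the change on the same aromatic carbon, a number 28 percentage points lower from compound 2 to compound 3 (beyond the scatter), which was beyond the scatter; the other two do not touch that carbon. Removing the nitro group is therefore expected to give a step upward, a number 25.8 percentage points higher from compound 3 to compound 4 (beyond the scatter), roughly back to the region of compound 2. Compound 4 is estimated at 0%, with a range from -25% to 20%.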

Compound 4, a percentage reported as inhibition, in the whole organism at one dose (the size of the read-out at that dose, not a potency): 0%
The estimate for compound 4 equals the measured number at the digits printed, within the range that was stated.
By their numbers in this assay, from the lowest: compound 3; then compounds 4, 2 and 1 (each within the scatter of the next, the first and the last beyond it).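

Amino in place of nitro on this aromatic carbon gives a number 25.8 percentage points higher from compound 3 to compound 4 (beyond the scatter) in this assay and so shows that the low number of compound 3 is not shared by an amino group here. Amino and methyl on this carbon cannot be told apart, with a number 2.2 percentage points lower from compound 2 to compound 4 (within the scatter) and, on the amide-type nitrogen, 4-aminophenyl in place of benzyl gives a number 11.3 percentage points lower from compound 1 to compound 4 (beyond the scatter). No measurement shown accounts for these steps.

Open, as far as these compounds go, is whether a carboxylic acid or chlorine on the same carbon would fall with the nitro or the amino compounds. Also open, from the compounds shown here alone, is what a phenethyl group on the amide-type nitrogen would give.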